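The source may report more compounds than this note shows. Statements on the series, on what has been measured and on what is new or still open speak of the compounds shown alone.

Working notes on the series. Among the measured compounds shown here, in a functional assay on MDA-MB-231 cells (Homo sapiens) for antiproliferative activity, with a stated time of 4 days (on this read-out higher numbers stand for weaker inhibition and lower numbers for stronger inhibition), compound 1 `COc1ccc(-c2[nH]c3ccc(F)cc3c2C=O)cc1` gives 540 nM and compound 2 `CCCCc1ccc2[nH]c(-c3ccc(OC)cc3)c(C=O)c2c1` gives 6.7 nM as the lower of the two numbers so far. For the measured compounds named here, the one measured step is an 81-fold lower number from compound 1 to compound 2 (1.91 log units; beyond the scatter) and it is large, with butyl in place of fluoro on an aromatic carbon. Compound 3 `COc1ccc(-c2[nH]c3ccc(CC(C)C)cc3c2C=O)cc1` has the same atoms as compound 2, joined differently, with isopropyl in place of propyl on a saturated chain carbon bound to an aromatic carbon as the change, which also reads butyl to isobutyl. Going by the values given here, no measured pair compares a straight chain with a branched one, so the only guide is that large step, where a whole chain replaced fluoro. A far smaller move is expected here. In this assay the expected step is a 1.5-fold higher number from compound 2 to compound 3 (0.17 log units; within the scatter) and it stays within the scatter. For compound 3 the estimated value is 10 nM with an expected range from 3.5 nM to 30 nM on this read-out.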

Compound 3, half-maximal inhibitory concentration: 72 nM
For compound 3 the middle estimate is 7.2-fold (0.86 log units) below the measured one; the measured number lies above the stated range.
By their numbers in this assay, from the lowest: compound 2; then compound 3; then compound 1.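

In this assay, the position tells apart two chains made of the same atoms joined differently: an 11-fold higher number from compound 2 to compound 3 (1.03 log units; beyond the scatter), with isopropyl in place of propyl on a saturated chain carbon bound to an aromatic carbon. The branched chain still improves on fluoro, with a 7.5-fold lower number from compound 1 to compound 3 (0.88 log units; beyond the scatter), but that step is modest, whereas an 81-fold lower number from compound 1 to compound 2 (1.91 log units; beyond the scatter) is large, so the gain depends on the shape of the chain and not only on a chain being present. Nothing available accounts for the difference between the straight and branched chains.

As far as these compounds go, this reading rests on a single straight-versus-branched pair, so it remains open whether it extends to other chains, such as pentyl or hexyl. Also open, from the compounds shown here alone, is how a cyclohexyl ring or an amine-bearing chain would fare on the same aromatic carbon.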